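Nitro to dimethylamino on a hydroxamic acid deacetylase inhibitor

The source may report more compounds than this note shows. Statements on the series, on what has been measured and on what is new or still open speak of the compounds shown alone.

Measured compounds:
compound 1, `Cn1cc(C(=O)c2ccccc2)cc1CCC(=O)NO`: 4.37 nM
compound 2, `Cn1cc(C(=O)c2ccc([N+](=O)[O-])cc2)cc1/C=C/C(=O)NO`: 2340 nM

In an assay on isolated protein with histone deacetylase HD2 (Zea mays) as the target (a higher number here means a weaker inhibitor, a lower number a stronger inhibitor), compound 1 gives 4.37 nM. Compound 2, which carries a nitro group on the benzoyl ring and an unsaturated linker to the hydroxamic acid, gives 2340 nM in this assay. For the measured compounds named here, of the two numbers, compound 2 thus stands at the highest, far beyond the scatter from compound 1; since the two structures differ in more than one place, no single step between them can be read off.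

Compound 3, `CN(C)c1ccc(C(=O)c2cc(/C=C/C(=O)NO)n(C)c2)cc1`, differs from compound 2 in one place: dimethylamino in place of nitro on an aromatic carbon, on an aromatic carbon of a six-membered aromatic ring of carbon only, para to a large group. Going by the values given here, no measured pair shows what this exchange does in this assay, so any expectation rests on the gap between compound 2 and compound 1 alone.

Compound 3 is expected to improve on compound 2, with the step from compound 2 to compound 3 estimated at a 5.9-fold lower number from compound 2 to compound 3 (0.77 log units; beyond the scatter) in this assay. Compound 3 is estimated at 400 nM, within a range from 40 nM to 4000 nM.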

Compound 3, inhibition constant: 1450 nM
Compound 3: the middle estimate sits 3.6-fold (0.56 log units) below what was measured; low and high end bracket the measured number.
By their numbers in this assay, from the lowest: compound 1; then compounds 3 and 2 (each within the scatter of the next).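

In this assay, for the compounds shown here, dimethylamino in place of nitro on an aromatic carbon, para to a large group, gives a 1.6-fold lower number from compound 2 to compound 3 (0.21 log units; within the scatter), the only step that can be read at this position. With the unsaturated linker and the rest of the structure held constant, this exchange of two groups of 3 heavy atoms each, one with 2 hydrogen-bond acceptors and the other with 1, does not move the number beyond the scatter, so the assay does not separate nitro from dimethylamino here. Nothing measured among these compounds speaks to the reason for this result.

Steps from compound 1 to compound 2 or compound 3 cannot be read, as each pair differs in more than one place, so the compounds shown do not separate the effect of the linker from that of the group on the benzoyl ring. Going by these compounds, it also remains open how a primary amine, a carboxylic acid or a methoxy group would behave at this position, and whether dimethylamino and nitro would remain as close on the linker of compound 1.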